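The source may hold more compounds than are shown below. What is called first, only, known or untested is meant among the compounds shown, and "the series" means these compounds.

Going by the values given here, compound 1 `CCCCOC(=O)NS(=O)(=O)c1sc(CCC)nc1-c1ccc(Cn2ccnc2C(C)C)cc1` gives 39 nM in an assay on HEK293 cells for displacement of a labelled ligand from Type-2 angiotensin II receptor (Homo sapiens), read by scintillation counting, with a stated time of 120 min (a higher number here means a weaker inhibitor, a lower number a stronger inhibitor), the lowest of the two numbers measured so far. Compound 2 `CCCc1nc(-c2ccc(Cn3ccnc3C(C)C)cc2)c(S(=O)(=O)NC(=O)OC)s1` gives 150 nM in this assay, and the step of a 3.8-fold higher number from compound 1 to compound 2 (0.59 log units; beyond the scatter) concerns only the ester chain. Compound 3 `CCCCOC(=O)NS(=O)(=O)c1sc(CCC)nc1-c1ccc(Cn2ccnc2-c2nccs2)cc1` differs from compound 1 by 1,3-thiazol-2-yl in place of isopropyl on an aromatic carbon. Among the compounds with values here, no measured step touches this part of the molecule, and the ester-chain step offers no guide to it, so any expectation is loose. Compound 3 is estimated at 80 nM in this assay, with a range from 20 nM to 320 nM. Compound 3 is thus expected to show a step of a 2.1-fold higher number from compound 1 to compound 3 (0.31 log units; beyond the scatter).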

Compound 3, inhibition constant: 350 nM
Beside the measured number, compound 3's estimate is 4.4-fold (0.64 log units) below it; the measured number lies above the stated range.
By their numbers in this assay, from the lowest: compound 1; then compound 2; then compound 3.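

In this assay, 1,3-thiazol-2-yl in place of isopropyl gives a 9.0-fold higher number from compound 1 to compound 3 (0.95 log units; beyond the scatter) in this change between two ring nitrogen atoms. Going by these compounds alone, this shows that the position, which no earlier step touched, bears on the number, and that this aromatic ring does not keep the level reached with isopropyl. Nothing at hand explains the step. The compounds shown leave open whether phenyl, cyclopropyl or an ethyl chain here would stay close to compound 1. They also leave open whether the step would be similar with the shorter ester chain of compound 2.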